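From phenylsulfanyl to phenylsulfonyl on a shared core

The source may hold more compounds than are shown below. What is called first, only, known or untested is meant among the compounds shown, and "the series" means these compounds.

Values in a functional assay for inhibition, with Homo sapiens as the target; on this read-out higher numbers stand for weaker binding and lower numbers for tighter binding:
- Compound 1 `COc1ccccc1OC(C)(C)C1OCC(C/C=C\CCC(=O)O)C(c2cccnc2)O1`: 224 nM
- Compound 2 `CC(C)(Oc1ccc(F)cc1[N+](=O)[O-])C1OCC(C/C=C\CCC(=O)O)C(c2cccnc2)O1`: 2.51 nM
- Compound 3 `CC(C)(Sc1ccccc1)C1OCC(C/C=C\CCC(=O)O)C(c2cccnc2)O1`: 200 nM

In this assay, the gap to compound 3 is small at the one end, a 1.1-fold lower number from compound 1 to compound 3 (0.05 log units; within the scatter), and large at the other, an 80-fold higher number from compound 2 to compound 3 (1.90 log units; beyond the scatter). Compound 4 `CC(C)(C1OCC(C/C=C\CCC(=O)O)C(c2cccnc2)O1)S(=O)(=O)c1ccccc1` has not been measured. It carries phenylsulfonyl in place of phenylsulfanyl on a saturated chain carbon bound to two saturated chain carbons and a saturated ring carbon. Within the data shown here, no measured step makes this change alone. The closest is a 1.1-fold lower number from compound 1 to compound 3 (0.05 log units; within the scatter), while an 89-fold lower number from compound 1 to compound 2 (1.95 log units; beyond the scatter), a different change, warns that large steps occur in this set. No step beyond the scatter is expected, so the expected step is a 1.7-fold lower number from compound 3 to compound 4 (0.22 log units; within the scatter). Compound 4 is estimated at 120 nM, with an expected range of 25 nM to 500 nM.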

Compound 4, dissociation constant: 3160 nM
Beside the measured number, compound 4's estimate is 26-fold (1.42 log units) below it, outside the stated range (above it).
By their numbers in this assay, from the lowest: compound 2; then compounds 3 and 1 (each within the scatter of the next); then compound 4.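

In this assay, this saturated chain carbon proves sensitive to a change at the sulfur alone, with the phenyl ring kept: a 16-fold higher number from compound 3 to compound 4 (1.20 log units; beyond the scatter). Phenylsulfonyl also stands apart from both oxygen-linked groups, with a 14-fold higher number from compound 1 to compound 4 (1.15 log units; beyond the scatter) and a 1300-fold higher number from compound 2 to compound 4 (3.10 log units; beyond the scatter), so the agreement of compound 1 and compound 3 did not mean that this position accepts any group carrying a phenyl ring. Nothing available explains this loss. From the compounds shown here alone, whether phenylsulfinyl would fall nearer compound 3 or compound 4 remains open, as does whether a 4-fluoro-2-nitrophenyl group on sulfur would approach compound 2.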